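The source may hold more compounds than are shown below. What is called first, only, known or untested is meant among the compounds shown, and "the series" means these compounds.

Of the compounds shown here, two share one core and have been tested in a functional assay on HL-60 cells (Homo sapiens) for inhibition, read by CCK-8 assay, with a stated time of 48 h; a higher number here means a weaker inhibitor, a lower number a stronger inhibitor. Compound 1 `Cc1cc(C)cc(NC(=O)NCCNS(=O)(=O)c2ccc(-c3ccccc3Oc3ccc([N+](=O)[O-])c([N+](=O)[O-])c3)s2)c1` gives 9100 nM in that setting. Compound 2 `COc1ccc(NC(=O)NCCNS(=O)(=O)c2sccc2-c2ccc(C)cc2Oc2ccc(O)c(O)c2)cc1` gives 6100 nM in this assay, and the gap between the two values lies within the usual scatter, so neither compound can be ranked ahead of the other. Compound 3 `O=C(NCCNS(=O)(=O)c1ccc(-c2ccccc2Oc2ccc([N+](=O)[O-])c([N+](=O)[O-])c2)s1)Nc1cc(Cl)cc(Cl)c1` differs from compound 1 only in the change (3,5-dichlorophenyl in place of 3,5-dimethylphenyl on an amide-type nitrogen). Among the measured compounds shown here, no measured pair shows such an exchange, so the expected step is small. The step expected a 1.2-fold lower number from compound 1 to compound 3 (0.08 log units; within the scatter) does not go beyond the scatter. Compound 3 is estimated at 7500 nM, with a range from 3000 nM to 19000 nM.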

Compound 3, half-maximal inhibitory concentration: 2300 nM
Compound 3: middle estimate off by 3.3-fold (0.51 log units), on the high side; measured number outside the range, below it.
By their numbers in this assay, from the lowest: compound 3; then compounds 2 and 1 (each within the scatter of the next).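

In this assay, 3,5-dichlorophenyl in place of 3,5-dimethylphenyl on an amide-type nitrogen gives a 4.0-fold lower number from compound 1 to compound 3 (0.60 log units; beyond the scatter), so the number at this place on the shared core does respond to the group it carries, which the earlier pair, differing in more than one place, could not show. Both groups have the same count of heavy atoms and the same ring, so the step goes with the exchange of methyl for chlorine alone. Nothing at hand accounts for its size. As far as these compounds go, whether 3,5-difluorophenyl or unsubstituted phenyl on the same nitrogen would stand with compound 3 or with compound 1 remains open.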